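The source may report more compounds than this note shows. Statements on the series, on what has been measured and on what is new or still open speak of the compounds shown alone.

Among the measured compounds shown here, compound 1, `COc1ccc(-c2nc(/N=C(\N)N(C)C)sc2-c2ccc(OC)cc2)cc1`, is the only member of this small set with a definite number: in a functional assay with Oryctolagus cuniculus as the target (on this read-out lower numbers stand for stronger inhibition and higher numbers for weaker inhibition), compound 1 gives 37 nM. Compound 2, `COc1ccc(-c2nc(/N=C(\N)N3CCOCC3)sc2-c2ccc(OC)cc2)cc1`, gives < 1000 nM in this assay, which is a limit of the assay and not a number. Compound 3, `COc1ccc(-c2nc(C(=O)N(C)C)sc2-c2ccc(OC)cc2)cc1`, gives < 100 nM in this assay, again a limit rather than a number. The steps a step that the limit leaves unreadable from compound 1 to compound 2 and a step that the limit leaves unreadable from compound 1 to compound 3 therefore cannot be sized, and the step that the two limits leave unreadable from compound 2 to compound 3 is likewise unreadable because of the limit of < 100 nM in this assay, at which 1 of the 3 values shown sits, and (the limit of < 1000 nM in this assay, at which 1 of the 3 values shown sits).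

Compound 4, `CCN(CC)C(=O)c1nc(-c2ccc(OC)cc2)c(-c2ccc(OC)cc2)s1`, differs from compound 1 in one place: a group of 7 heavy atoms (5 carbon, 1 nitrogen, 1 oxygen; no ring) in place of a group of 6 heavy atoms (3 carbon, 3 nitrogen; no ring), on an aromatic carbon. For the measured compounds named here, the only measured step that touches this position, from compound 1 to compound 3, is unreadable, so no size or direction beyond the scatter can be drawn from it. Compound 3, with its related carbamoyl group, stays under its limit, which is the sole anchor. Compound 4 is expected to give about 60 nM, between 15 nM and 250 nM, meaning an estimated step of a 1.6-fold higher number from compound 1 to compound 4 (0.21 log units; within the scatter).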

Compound 4, half-maximal inhibitory concentration: < 10 nM
Compound 4: no number, only a limit; the forecaster's own chance of this, stated with the estimate: 30%; at least 6.0-fold (0.77 log units) between middle value and limit.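

The value of compound 4 in this assay, < 10 nM, is a limit of the assay and not a number. Even so, it gives the first readable step at this position on the aromatic carbon: diethylcarbamoyl in place of the group of compound 1 yields an at least 3.7-fold lower number from compound 1 to compound 4 (0.56 log units; beyond the scatter), so the group that enters, with 0 hydrogen-bond donors against 1 in the group that leaves, costs nothing here and goes with a lower number. The steps from compound 2 and compound 3 to compound 4 cannot be read, because limits stand at both ends of each: the limit of < 10 nM in this assay, at which 1 of the 4 values shown sits.

Going by these compounds, whether diethylamino on the carbonyl carbon does better than the dimethylamino of compound 3 therefore stays open. On these data alone, how a carboxylic acid, or a longer chain such as dipropylamino on the same carbonyl carbon, would fare at this position also stays open.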